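Indole carboxamide series: swap of the acyl aryl group

This account rests on a few compounds, and the source may have more. Where it says the series, first, only, none or still open, it means among the compounds named here.

Measured compounds:
compound 1 `O=C(NCc1cccc(Cn2cnc3ccccc32)c1)c1cc2ccccc2[nH]1` 72 nM
compound 2 `Cc1ccc2[nH]c(C(=O)NCc3cccc(Cn4cnc5ccccc54)c3)cc2c1` 636 nM
compound 3 `O=C(NCc1cccc(Cn2cnc3ccccc32)c1)c1cc2cc(O)ccc2[nH]1` 781 nM

In an assay for inhibition of Indoleamine 2,3-dioxygenase 1 (Homo sapiens), read by HPLC, with a stated time of 48 h (on this read-out lower numbers stand for stronger inhibition and higher numbers for weaker inhibition), compound 3 has the highest number of the three. Its step to compound 2 is within the scatter, while compound 1 stands apart: an 11-fold higher number from compound 1 to compound 3 (1.04 log units; beyond the scatter) and an 8.8-fold higher number from compound 1 to compound 2 (0.95 log units; beyond the scatter) both run upward from compound 1.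

Compound 4 `Cc1ccc(C(=O)NCc2cccc(Cn3cnc4ccccc43)c2)cc1` differs from compound 3 by 4-methylphenyl in place of 5-hydroxy-1H-indol-2-yl on a carbonyl carbon. Neither measured step bears directly on this change: both alter a substituent on the ring that now leaves, none replaces the ring itself. The hydroxy is lost, which in an 11-fold higher number from compound 1 to compound 3 (1.04 log units; beyond the scatter) went with a higher number, but the whole bicyclic amide is also lost, so the direction is open. An upward step is expected in this assay, a 1.9-fold higher number from compound 3 to compound 4 (0.28 log units; within the scatter), giving compound 4 an estimated 1500 nM (range 300 nM to 8000 nM).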

Compound 4, half-maximal inhibitory concentration: 327 nM
Estimate against measurement, compound 4: 4.6-fold (0.66 log units) above; measured number inside the range.
By their numbers in this assay, from the lowest: compound 1; then compounds 4, 2 and 3 (each within the scatter of the next, the first and the last beyond it).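

In this assay, a single-ring 4-methylphenyl on the carbonyl carbon does not fall behind the substituted indoles: a 2.4-fold lower number from compound 3 to compound 4 (0.38 log units; beyond the scatter), while a 1.9-fold lower number from compound 2 to compound 4 (0.29 log units; within the scatter) stays within the scatter. The unsubstituted 1H-indol-2-yl alone keeps a lead over it, with a 4.5-fold higher number from compound 1 to compound 4 (0.66 log units; beyond the scatter), so the bicyclic group is not needed for activity at the level of compounds 2 and 3, though the best value here still carries it. No supporting evidence on the origin of these shifts is available.

Open, as far as these compounds go, is whether a plain phenyl, or an amine or carboxylic acid in place of the methyl, would hold this level. Also open, from the compounds shown here alone, is whether any substituent on the indole can match compound 1.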